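The compounds below may be only part of what the source reports. "The series", "measured", "known", "first", "only" and "open" are said of these compounds alone.

Working notes on the series

Four compounds share an aminophenyl amide bearing an arylthio-methyl substituent, differing in the arene on the sulfur and in the linker that joins the amide to the central ring. Compound 1 `Nc1ccccc1NC(=O)/C=C/c1ccc(CSc2cccc(F)c2)cc1` and compound 2 `CCc1ccc(SCc2ccc(/C=C/C(=O)Nc3ccccc3N)cc2)cc1` carry the longer core; compound 3 `CCc1ccc(SCc2ccc(C(=O)Nc3ccccc3N)cc2)cc1` and compound 4 `Nc1ccccc1NC(=O)c1ccc(CSc2cccc(F)c2)cc1` carry the shorter one. The difference between the two cores is not broken down here.

In a functional assay on HCT-116 cells (Homo sapiens) for inhibition, read by CCK-8 assay, with a stated time of 72 h, tested at 8 uM (a lower number here means less inhibition of growth, a higher number more inhibition of growth at the concentration tested), compound 2 gives 2.68%, compound 1 gives 3.22% and compound 3 gives 79.1%. Compound 3 stands highest of the three measured, and its distance from compound 1 and from compound 2 lies beyond the scatter in both cases. Compound 1 and compound 2 lie within the scatter of each other, so no order between them is claimed.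

The change from compound 2 to compound 1 is 3-fluorophenyl in place of 4-ethylphenyl on a sulfur, and the step it made was a number 0.5 percentage points higher from compound 2 to compound 1 (within the scatter), within the scatter. The change from compound 3 to compound 4 is 3-fluorophenyl in place of 4-ethylphenyl on a sulfur, the same change at the same kind of place. Because the step of a number 0.5 percentage points higher from compound 2 to compound 1 (within the scatter) was flat, the same change on the shorter core is expected to be roughly flat as well, with the reservation that it has been seen only once and on a core that sits low in this assay. The expected step from compound 3 to compound 4 is a number 2.1 percentage points lower from compound 3 to compound 4 (within the scatter). Compound 4 is therefore estimated at 77%, in a range from 58% to 92%.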

Compound 4, percent growth inhibition at one concentration: 81.4%
The estimate for compound 4 lay 4.4 percentage points below the measured number, and the stated range covers the measured number.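

In this assay, 3-fluorophenyl in place of 4-ethylphenyl on a sulfur gives a number 2.3 percentage points higher from compound 3 to compound 4 (within the scatter), and the change reads the same on both cores: the same change on two cores in this assay, a number 0.5 percentage points higher (within the scatter) from compound 2 to compound 1 and a number 2.3 percentage points higher (within the scatter) from compound 3 to compound 4, 1.8 percentage points apart, within the scatter of two such steps

The flat result therefore holds on two cores that sit far apart in this read-out, with compound 2 at 2.68% and compound 3 at 79.1%, so the earlier flat step was not peculiar to the core that sits low. It does not show that this exchange is without effect in general: the evidence is two matched pairs, one pair of groups, one cell line and one tested concentration, and a number near the top or the bottom of this read-out may not reveal a smaller difference that a full concentration series would.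

The compounds shown leave open how an arene on the sulfur carrying an amine or a carboxylic acid, or a longer chain in place of the ethyl group, would read in this assay. Also open, as far as these compounds go, is which feature of the longer core goes with its low numbers, as the two cores differ here as a whole and that difference is not broken down.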